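Trifluoromethoxy for trifluoromethyl in a thioether amide series

The source may hold more compounds than are shown below. What is called first, only, known or untested is meant among the compounds shown, and "the series" means these compounds.

Measured in a functional assay on CWR22R cells (Homo sapiens) for antiproliferative activity, read by propidium iodide staining, with a stated time of 96 h; a higher number here means a weaker inhibitor, a lower number a stronger inhibitor:
- compound 1 `CC(O)(CSc1cccc(C(F)(F)F)c1)C(=O)Nc1ccc(S(F)(F)(F)(F)F)cc1`: 23400 nM
- compound 2 `CC(O)(CSc1cccc(OC(F)(F)F)c1)C(=O)Nc1ccc(S(F)(F)(F)(F)F)cc1`: 14000 nM
- compound 3 `CC(O)(CSc1ccccc1C(F)(F)F)C(=O)Nc1cccc(S(F)(F)(F)(F)F)c1`: 13200 nM

Compound 1 and compound 2 share a core and differ by trifluoromethoxy in place of trifluoromethyl on an aromatic carbon; in this assay this gave a 1.7-fold lower number from compound 1 to compound 2 (0.22 log units; within the scatter). Compound 3 has the same atoms as compound 1 joined differently; the difference between the two cores is not broken down here. Compound 4 `CC(O)(CSc1ccccc1OC(F)(F)F)C(=O)Nc1cccc(S(F)(F)(F)(F)F)c1` stands to compound 3 as compound 2 stands to compound 1, by trifluoromethoxy in place of trifluoromethyl on an aromatic carbon. The two changes are the same kind of change, not the same: in one the place is meta to a large group, in the other ortho to a large group. The step from compound 3 to compound 4 in this assay is expected to be a 1.3-fold lower number from compound 3 to compound 4 (0.12 log units; within the scatter), small because the earlier change gave a 1.7-fold lower number from compound 1 to compound 2 (0.22 log units; within the scatter). Compound 4 is therefore expected to give 10000 nM, within 4000 nM to 26000 nM.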

Compound 4, half-maximal inhibitory concentration: 13900 nM
Compound 4: the middle estimate sits 1.4-fold (0.14 log units) below what was measured; the range from low to high includes it.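

In this assay, trifluoromethoxy in place of trifluoromethyl on an aromatic carbon, ortho to a large group, gives a 1.1-fold higher number from compound 3 to compound 4 (0.02 log units; within the scatter). Set beside the earlier step, the change reads alike on the two cores as far as these data can tell: the same change on two cores in this assay, a 1.7-fold lower number (0.22 log units; within the scatter) from compound 1 to compound 2 and a 1.1-fold higher number (0.02 log units; within the scatter) from compound 3 to compound 4, 1.8-fold (0.25 log units) apart, within the scatter of two such steps. Neither step establishes a gain or a loss on its own core, and two pairs cannot exclude a difference between the cores smaller than the scatter, so this is no evidence of a transferable effect.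

Open, as far as these compounds go, is how a nitrile or a methoxy group would read at the same aromatic carbon in this assay. Also open, from the compounds shown here alone, is whether an amine in place of the hydroxyl would shift the number on either core.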